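Swapping the bicyclic amide for an oxolane ring

This account rests on a few compounds, and the source may have more. Where it says the series, first, only, none or still open, it means among the compounds named here.

Compound 1 `Cc1cc(N2CC[C@H](N3CCC[C@@H]3C)C2)ccc1NC(=O)C1CCCO1`: 7.33 nM
Compound 2 `Cc1cc(N2CCC(N3CCCC3C)C2)ccc1NC(=O)C1CCOCC1`: 6.8 nM
Compound 3 `Cc1cc(N2CCC(N3CCCC3C)C2)ccc1NC(=O)C1CC2CCC1C2`: 19.9 nM

In an assay on CHO cells for displacement of a labelled ligand from histamine receptor H3 (Macaca mulatta) (a lower number here means a stronger inhibitor, a higher number a weaker inhibitor), compound 3 gives the highest number of the three measured, while compound 1 and compound 2 sit close together below it. Compound 4 `Cc1cc(N2CCC(N3CCCC3C)C2)ccc1NC(=O)C1CCCO1` has not been measured. It differs from compound 3 in that (a group of 5 heavy atoms (4 carbon, 1 oxygen; one five-membered non-aromatic ring with 1 hetero atom) in place of a group of 7 heavy atoms (7 carbon; 2 five-membered non-aromatic rings of carbon only), on a carbonyl carbon). For the measured compounds named here, the one step that bears on this is the change in the opposite direction, a 2.9-fold higher number from compound 2 to compound 3 (0.47 log units; beyond the scatter), where a ring with an oxygen gave way to the all-carbon bicyclic group. Compound 1, which already carries the oxolan-2-yl group on its carbonyl carbon, also gives a lower number than compound 3. A reversal of that modest step is therefore expected, with compound 4 estimated at 8 nM (range 3.5 nM to 18 nM), a step of a 2.5-fold lower number from compound 3 to compound 4 (0.40 log units; beyond the scatter).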

Compound 4, inhibition constant: 7.34 nM
Estimate against measurement, compound 4: 1.1-fold (0.04 log units) above; the measured number falls inside the stated range.
By their numbers in this assay, from the lowest: compounds 2, 1 and 4 (each within the scatter of the next); then compound 3.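

On the carbonyl carbon, the oxolan-2-yl group undoes the loss seen with the all-carbon bicyclic group, giving a 2.7-fold lower number from compound 3 to compound 4 (0.43 log units; beyond the scatter). The two oxygen-bearing rings cannot be told apart, with a 1.1-fold higher number from compound 2 to compound 4 (0.03 log units; within the scatter). Stereochemistry does not separate the oxolane compounds either, with a 1.0-fold higher number from compound 1 to compound 4 (0.00 log units; within the scatter), and the sole difference between them is this: the fact that one of compounds 1 and 4 is drawn with a defined configuration and the other without, at the place where they differ

On these data alone, it remains open whether the ring oxygen or the single-ring shape matters, since both differ from the bicyclic group. How a cyclopentyl ring or an amine such as piperidin-4-yl would compare is also unknown.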